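The compounds below may be only part of what the source reports. "The series", "measured", "known", "first", "only" and "open" are said of these compounds alone.

Compound 1 `CC(C)=CCC/C(C)=C/CC/C(C)=C/CC[C@@H]1[C@@]2(C)CCC(=O)C(C)(C)[C@@H]2CC[C@@]1(C)O` is the unsubstituted ketone of this series; in a functional assay on A549 cells (Homo sapiens) for cytotoxicity, read by MTT assay, with a stated time of 48 h (on this read-out higher numbers stand for weaker inhibition and lower numbers for stronger inhibition), compound 1 gives 12000 nM. Two oxime ethers built on it follow. Compound 2 `CC(C)=CCC/C(C)=C/CC/C(C)=C/CC[C@@H]1[C@@]2(C)CC/C(=N\OCc3cn(-c4ccc(F)cc4)nn3)C(C)(C)[C@@H]2CC[C@@]1(C)O` gives 18000 nM in this assay, and compound 3 `CC(C)=CCC/C(C)=C/CC/C(C)=C/CC[C@@H]1[C@@]2(C)CC/C(=N\OCc3cn(-c4ccccc4C#N)nn3)C(C)(C)[C@@H]2CC[C@@]1(C)O` gives 20000 nM. The number for compound 3 is the highest of the three, yet it lies within the scatter of both others, so no order among them can be read. Among the compounds with values here, the one measured step that bears on a change at this position is a 1.1-fold higher number from compound 2 to compound 3 (0.05 log units; within the scatter). The next change is 2,3,4-trifluorophenyl in place of 2-cyanophenyl on an aromatic nitrogen, giving compound 4 `CC(C)=CCC/C(C)=C/CC/C(C)=C/CC[C@@H]1[C@@]2(C)CC/C(=N\OCc3cn(-c4ccc(F)c(F)c4F)nn3)C(C)(C)[C@@H]2CC[C@@]1(C)O`. Since the aryl swap on the triazole nitrogen left the number essentially unchanged, compound 4 is expected to give 20000 nM, between 10000 nM and 40000 nM. The step of no change at the digits printed from compound 3 to compound 4 (within the scatter) that this estimate means is expected to stay within the scatter.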

Compound 4, half-maximal inhibitory concentration: 26900 nM
The estimate for compound 4 lay 1.3-fold (0.13 log units) below the measured number; low and high end bracket the measured number.
By their numbers in this assay, from the lowest: compounds 1, 2, 3 and 4 (each within the scatter of the next, the first and the last beyond it).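

In this assay the 2,3,4-trifluorophenyl group on this aromatic nitrogen shows a 1.3-fold higher number from compound 3 to compound 4 (0.13 log units; within the scatter) and a 1.5-fold higher number from compound 2 to compound 4 (0.17 log units; within the scatter) and so cannot be told apart from either earlier aryl group. Three aryl groups now stand at this position without a readable difference, and losing the nitrile of 2-cyanophenyl or adding fluorines to the single fluorine of 4-fluorophenyl does not separate them. The compounds shown leave open whether a group other than a substituted phenyl, such as an aminoalkyl chain or a carboxylic acid, would move the number at this nitrogen. Nothing measured here explains these numbers.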